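A Trifluoroacetyl Piperidine Analogue on the Shared Core

A few compounds are considered here, and "the series" means these few. Any claim that something is new, unique, unknown or untested is made for them only; others in the source may bear on it.

Of the compounds shown here, two have been measured in a functional assay on isolated protein for inhibition of Glucose-dependent insulinotropic receptor (Rattus norvegicus), read by HTRF and cAMP accumulation; on this read-out lower numbers stand for an effect already at smaller amounts and higher numbers for an effect only at larger amounts of compound. Compound 1 `Cc1nc(S(C)(=O)=O)ccc1Oc1ncnc(OC2CCN(C(=O)O[C@H](C)CF)CC2)c1F` gives 1520 nM. Compound 2 `Cc1nc(S(C)(=O)=O)ccc1Oc1ncnc(OC2CCN(C(=S)OC3(C)CC3)CC2)c1F` gives 48.8 nM, the lowest of the two numbers; its nearest neighbour is compound 1, and the step of a 31-fold lower number from compound 1 to compound 2 (1.49 log units; beyond the scatter) is large and beyond the scatter. Compound 3 `Cc1nc(S(C)(=O)=O)ccc1Oc1ncnc(OC2CCN(C(=O)C(F)(F)F)CC2)c1F` has not yet been measured in this assay. Compound 3 differs from compound 2 in one place: a group of 6 heavy atoms (2 carbon, 1 oxygen, 3 fluorine; no ring) in place of a group of 7 heavy atoms (5 carbon, 1 oxygen, 1 sulfur; one three-membered non-aromatic ring of carbon only), on an amine nitrogen in a ring. For the measured compounds named here, only one measured step bears on this position, a 31-fold lower number from compound 1 to compound 2 (1.49 log units; beyond the scatter), and it shows that exchanging the group on this ring nitrogen can move the number well beyond the scatter. That step, however, changed a different pair of groups, so it fixes the direction only loosely. Because compound 2 gives 48.8 nM and its group is the only one so far tied to a low number, the step of an 8.2-fold higher number from compound 2 to compound 3 (0.91 log units; beyond the scatter) is expected to go toward a higher number. Compound 3 is therefore estimated at 400 nM, with a likely range from 100 nM to 1600 nM.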

Compound 3, half-maximal effective concentration: 880 nM
The estimate for compound 3 lay 2.2-fold (0.34 log units) below the measured number; the range from low to high includes it.
By their numbers in this assay, from the lowest: compound 2; then compounds 3 and 1 (each within the scatter of the next).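

With the (trifluoromethyl)carbonyl group on the ring nitrogen, the result is an 18-fold higher number from compound 2 to compound 3 (1.26 log units; beyond the scatter), so a second group, unlike the first, also ends far from the low number of compound 2. The comparison of the two groups without a ring gives a 1.7-fold lower number from compound 1 to compound 3 (0.24 log units; within the scatter), and in this assay these two very different groups cannot be told apart, which leaves the group of compound 2 alone among the three in reaching a low number. Nothing available on these compounds gives a reason for either step.

The group of compound 2 differs from the other two in carrying both a sulfur atom and a three-membered carbon ring, so the compounds shown cannot say whether the sulfur, the ring or the two together go with the low number. A group that keeps the three-membered ring but has oxygen in place of the sulfur would separate these two features, while a simple acetyl group or a longer carbon chain on the same nitrogen would show how far the other two results extend.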